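Carbamate capping of the phenol across two linker lengths

The source may hold more compounds than are shown below. What is called first, only, known or untested is meant among the compounds shown, and "the series" means these compounds.

Measured in an assay on cells for displacement of a labelled ligand from melatonin receptor type 1A (Homo sapiens), using the Cheng-Prusoff equation, with a stated time of 90 min; a lower number here means a stronger inhibitor, a higher number a weaker inhibitor:
compound 1 `CC(=O)NCCN(C)c1cccc(OCCCCCCOc2cccc(OC(=O)NC3CCCCC3)c2)c1`: 27.5 nM
compound 2 `CC(=O)NCCN(C)c1cccc(OCCCCCCOc2cccc(O)c2)c1`: 58.9 nM
compound 3 `CC(=O)NCCN(C)c1cccc(OCCCCOc2cccc(O)c2)c1`: 186 nM

Compound 3 gives the highest number of the three in this assay; its difference from compound 2 is in the core and is not broken down here. Compound 1 differs from compound 2 by cyclohexylcarbamoyl in place of hydrogen on an oxygen on an aromatic ring, a change that gave a 2.1-fold lower number from compound 2 to compound 1 (0.33 log units; beyond the scatter).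

Compound 4 `CC(=O)NCCN(C)c1cccc(OCCCCOc2cccc(OC(=O)NC3CCCCC3)c2)c1` is not yet measured. It differs from compound 3 by cyclohexylcarbamoyl in place of hydrogen on an oxygen on an aromatic ring; the place is the same word for word as before, so this is the same change on the other core. Among the measured compounds shown here, for compound 4 the expected step is a 2.1-fold lower number from compound 3 to compound 4 (0.33 log units; beyond the scatter), taken to match a 2.1-fold lower number from compound 2 to compound 1 (0.33 log units; beyond the scatter) since only that one step is known for this change. Compound 4 is expected at 88 nM, within 40 nM to 190 nM.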

Compound 4, inhibition constant: 34.7 nM
Compound 4: middle estimate off by 2.5-fold (0.40 log units), on the high side, and the stated range ends above it.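

In this assay, placing cyclohexylcarbamoyl on the oxygen on an aromatic ring of the core of compound 3 gave a 5.4-fold lower number from compound 3 to compound 4 (0.73 log units; beyond the scatter). The change lowers the number on both cores, and the two steps do not differ beyond what repeated measurement allows: the same change on two cores in this assay, a 2.1-fold lower number (0.33 log units; beyond the scatter) from compound 2 to compound 1 and a 5.4-fold lower number (0.73 log units; beyond the scatter) from compound 3 to compound 4, 2.5-fold (0.40 log units) apart, within the scatter of two such steps. The direction therefore carried over between these two cores, but two steps cannot show whether the size of the step depends on the core, and they support no rule beyond these four compounds.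

Still open, as far as these compounds go, is whether a methylcarbamoyl or phenylcarbamoyl group on that oxygen would lower the number in the same way. Also open, from the compounds shown here alone, is whether cyclohexylcarbamoyl would do so on a core with a longer chain.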